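A few compounds are considered here, and "the series" means these few. Any claim that something is new, unique, unknown or untested is made for them only; others in the source may bear on it.

Among the measured compounds shown here, compound 1, `C#CCN(Cc1ccc(OCc2cccc(F)c2)cc1)[C@@H](C)C(N)=O`, stands at the weaker end of the two numbers measured so far in an assay on Sf9 cells for inhibition of Amine oxidase [flavin-containing] A (Homo sapiens), with stated times of 15 min and 60 min; on this read-out lower numbers stand for stronger inhibition and higher numbers for weaker inhibition: in this assay compound 1 gives 7790 nM, the highest number of the pair. Compound 2, `NC(=O)[C@@H]1CCN1Cc1ccc(OCc2cccc(F)c2)cc1Cl`, is built on a different core and gives 2130 nM in this assay, a lower number whose gap to compound 1 lies beyond the scatter, though the two structures differ in more than one place, so no single change can be read from them. Compound 3, `C#CCN(Cc1ccc(OCc2cccc(F)c2)cc1C)[C@@H](C)C(N)=O`, is a close relative of compound 1; the change is methyl in place of hydrogen on an aromatic carbon, a methyl in place of hydrogen on an aromatic carbon. For the measured compounds named here, no measured pair isolates a change of this kind, so the expected step is modest: it is estimated as a 1.6-fold lower number from compound 1 to compound 3 (0.19 log units; within the scatter), a slight move toward a lower number that may not exceed the scatter. On this basis compound 3 is expected to give 5000 nM in this assay, with a likely range from 1500 nM to 15000 nM.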

Compound 3, half-maximal inhibitory concentration: 6400 nM
The estimate for compound 3 lay 1.3-fold (0.11 log units) below the measured number, and the stated range covers the measured number.
By their numbers in this assay, from the lowest: compound 2; then compounds 3 and 1 (each within the scatter of the next).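

Methyl in place of hydrogen on this aromatic carbon, ortho to a large group, gives a 1.2-fold lower number from compound 1 to compound 3 (0.09 log units; within the scatter) in this assay, a step within the scatter. This is the first reading of a single change in the series, since compounds 1 and 2 differ in more than one place, and it shows that this added carbon leaves compound 3 indistinguishable from compound 1 on this read-out. (No available measurement offers a reason for this result)

One methyl says little about the position as a whole, and an ethyl, a methoxy or an amine on the same carbon could give a different answer. On these data alone, whether the same methyl would also leave the number within the scatter on the core of compound 2 also stays open.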